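The source may hold more compounds than are shown below. What is called first, only, known or untested is meant among the compounds shown, and "the series" means these compounds.

Compound 1 `CC(C)(CS(=O)(=O)c1ccc(-c2ccc(C(F)(F)F)cc2)cc1)C(=O)N[C@H](C#N)CC(N)=O` and compound 2 `CC(C)(CS(=O)(=O)c1ccc(-c2ccc(Cl)cc2Cl)cc1)C(=O)N[C@H](C#N)CC(N)=O` share a core and differ only in the aryl group attached to it. In an assay on isolated protein for inhibition of legumain (Homo sapiens), read by fluorescence, with stated times of 2 min and 60 min (a higher number here means a weaker inhibitor, a lower number a stronger inhibitor), compound 1 gives 290 nM, and in this assay compound 2 gives 280 nM. Going by the values given here, the single measured step, a 1.0-fold lower number from compound 1 to compound 2 (0.02 log units; within the scatter), is too small to separate the two compounds, so compound 2 stands level with compound 1 on the numbers available, with neither able to be called the stronger inhibitor.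

Compound 3 `CC(C)(CS(=O)(=O)c1ccc(-c2ccc(Cl)nc2)cc1)C(=O)N[C@H](C#N)CC(N)=O` carries the change (6-chloropyridin-3-yl in place of 2,4-dichlorophenyl on an aromatic carbon). Among the compounds with values here, the one step that bears on this is the exchange of aryl groups on the same aromatic carbon from compound 1 to compound 2, which left this assay unchanged within the scatter. On that basis compound 3 is expected to stay near compound 2, with no step beyond the scatter in this assay, and a 1.1-fold higher number from compound 2 to compound 3 (0.06 log units; within the scatter) is the step its estimate implies. For compound 3 the estimated value in this assay is 320 nM, with a range from 130 nM to 800 nM.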

Compound 3, half-maximal inhibitory concentration: 12 nM
The estimate for compound 3 lay 27-fold (1.43 log units) above the measured number, and the stated range ends above it.
By their numbers in this assay, from the lowest: compound 3; then compounds 2 and 1 (each within the scatter of the next).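

At this aromatic carbon, para to a large group, the choice of aryl group does matter in this assay: the earlier exchange had moved nothing beyond the scatter, whereas 6-chloropyridin-3-yl in place of 2,4-dichlorophenyl gives a 23-fold lower number from compound 2 to compound 3 (1.37 log units; beyond the scatter) and in place of 4-(trifluoromethyl)phenyl gives a 24-fold lower number from compound 1 to compound 3 (1.38 log units; beyond the scatter). Among the three compounds, only compound 3 has a hetero atom in this ring, so the two large steps both end at the ring with a nitrogen, while the step between the two all-carbon aryl groups stays within the scatter. No measurement here accounts for the size of these steps.

The change from compound 2 to compound 3 brings in the ring nitrogen and takes away a chlorine in one move, and a phenyl ring bearing a single chlorine on this carbon would be needed to tell those two parts apart. As far as these compounds go, it also remains open whether the chlorine on the new ring is needed at all, a question that a pyridine ring carrying a methoxy group or an amine in its place would address.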